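A few compounds are considered here, and "the series" means these few. Any claim that something is new, unique, unknown or untested is made for them only; others in the source may bear on it.

Measured compounds in a functional assay on IMR-32 cells (Homo sapiens) for inhibition, with a stated time of 48 h, tested at 50 uM; on this read-out higher numbers stand for more inhibition of growth at the one concentration tested and lower numbers for less inhibition of growth:
- compound 1, `C=C[C@@](C)(/C=C/c1ccc(OC(C)=O)cc1)CCC=C(C)C`, gives 71%
- compound 2, `C=C[C@@](C)(/C=C/c1ccc(OC(=O)CC)cc1)CCC=C(C)C`, gives 63%
- compound 3, `C=C[C@@](C)(/C=C/c1ccc(OC(=O)CCC)cc1)CCC=C(C)C`, gives 54%

Compound 3 holds the lowest of the three numbers. Against compound 2 the gap lies within the scatter, so no order between these two can be read; against compound 1 the step is a number 17 percentage points lower from compound 1 to compound 3 (beyond the scatter), which stands beyond the scatter.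

Compound 4, `C=C[C@@](C)(/C=C/c1ccc(OC(=O)CCCCC)cc1)CCC=C(C)C`, is not yet measured. It differs from compound 3 by ethyl in place of hydrogen on a saturated chain carbon, three bonds along the chain from a carbonyl carbon.

The measured steps that bear on this change are those that lengthen the same ester chain. The step of a number 9 percentage points lower from compound 2 to compound 3 (within the scatter) lies within the scatter, as does a number 8 percentage points lower from compound 1 to compound 2 (within the scatter). For the measured compounds named here, the step of a number 17 percentage points lower from compound 1 to compound 3 (beyond the scatter), which brings in the same ethyl group as the present change, is beyond the scatter and modest, and it is the only step in the set that clears the scatter; it runs downward as the chain grows. With three compounds only, this is a thin basis. Still, a further extension of the chain is expected to lower the number in this assay modestly, by about a number 10 percentage points lower from compound 3 to compound 4 (within the scatter). For compound 4 the expected value is 44%, with a range from 30% to 58%.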

Compound 4, percent growth inhibition at one concentration: 19%
Compound 4: middle estimate off by 25 percentage points, on the high side, outside the stated range (below it).
By their numbers in this assay, from the lowest: compound 4; then compounds 3, 2 and 1 (each within the scatter of the next, the first and the last beyond it).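

In this assay, for the compounds shown here, the ester chain at this position proves less forgiving than the shorter members suggested: ethyl in place of hydrogen, three bonds along the chain from a carbonyl carbon, gives a number 35 percentage points lower from compound 3 to compound 4 (beyond the scatter) and this is a large step, whereas the earlier steps along the chain were within the scatter or modest. The fall is also large when read from the shorter esters, as a number 44 percentage points lower from compound 2 to compound 4 (beyond the scatter) and a number 52 percentage points lower from compound 1 to compound 4 (beyond the scatter) show, and compound 4 alone stands beyond the scatter of all three other compounds. Going by these compounds alone, the numbers therefore do not fall evenly along this chain of four compounds, since the single extension from compound 3 to compound 4 is the first one-step change of this kind to clear the scatter by a large margin.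

From the compounds shown here alone, whether the number keeps falling with a longer chain, or what an amide or a carboxylic acid in place of the ester would give at this one concentration, stays open. No measurement at hand gives a reason for the sharp fall at compound 4.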